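The source may report more compounds than this note shows. Statements on the series, on what has been measured and on what is new or still open speak of the compounds shown alone.

Measured compounds:
Compound 1, `CCN(CC)CCNC(=O)c1ccc(C(CC)(CC)c2ccc(OCS(=O)(=O)c3ccccc3)c(C)c2)n1CC`: 4680 nM
Compound 2, `CCn1c(C(=O)N[C@H](CO)C(C)C)ccc1C(CC)(CC)c1ccc(OCS(=O)(=O)c2ccccc2)c(C)c1`: 25500 nM

Of the compounds shown here, two have so far been measured in a functional assay on MCF7 cells (Homo sapiens) for antiproliferative activity, read by MTT assay, with a stated time of 24 h; a lower number here means a stronger inhibitor, a higher number a weaker inhibitor. Compound 1 `CCN(CC)CCNC(=O)c1ccc(C(CC)(CC)c2ccc(OCS(=O)(=O)c3ccccc3)c(C)c2)n1CC` gives 4680 nM, and compound 2 `CCn1c(C(=O)N[C@H](CO)C(C)C)ccc1C(CC)(CC)c1ccc(OCS(=O)(=O)c2ccccc2)c(C)c1` gives 25500 nM. Both share the same core and differ only in the group on the amide-type nitrogen; the step of a 5.4-fold higher number from compound 1 to compound 2 (0.74 log units; beyond the scatter) leaves compound 2 with the higher of the two numbers, making it the weaker inhibitor in this assay.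

Compound 3 `CCn1c(C(=O)N[C@H](C(=O)O)C(C)C)ccc1C(CC)(CC)c1ccc(OCS(=O)(=O)c2ccccc2)c(C)c1` keeps everything in compound 2 except one group: carboxy in place of hydroxymethyl on a saturated chain carbon bound to an amide-type nitrogen and a saturated chain carbon. Among the measured compounds shown here, no measured step bears directly on this change. For the measured compounds named here, the single known step exchanged the whole substituent on the amide-type nitrogen, whereas here only one group at the end of that substituent is altered, so that step offers little guidance. With nothing directly comparable, a step of modest size in this assay is expected for compound 3, a 1.4-fold higher number from compound 2 to compound 3 (0.14 log units; within the scatter), toward a somewhat higher number, though the range is wide. Compound 3 is therefore estimated at 35000 nM, between 12000 nM and 100000 nM.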

Compound 3, half-maximal inhibitory concentration: 24500 nM
Compound 3: middle estimate off by 1.4-fold (0.15 log units), on the high side, within the range that was stated.
By their numbers in this assay, from the lowest: compound 1; then compounds 3 and 2 (each within the scatter of the next).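

In this assay, putting carboxy in place of hydroxymethyl on a saturated chain carbon bound to an amide-type nitrogen and a saturated chain carbon gives a step that lies within the scatter (a 1.0-fold lower number from compound 2 to compound 3 (0.02 log units; within the scatter)), so compound 2 and compound 3 cannot be told apart in this measurement. The wider exchange on the amide-type nitrogen now has a second example: 1-carboxy-2-methylpropyl in place of 2-(diethylamino)ethyl also gives a step beyond the scatter (a 5.2-fold higher number from compound 1 to compound 3 (0.72 log units; beyond the scatter)), so among these three compounds, the one carrying 2-(diethylamino)ethyl has the lowest number. Nothing available here explains either result.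

The compounds shown leave open whether a methyl ester or a primary amide at the same carbon would read like hydroxymethyl and carboxy, and whether a longer chain in place of the 2-methylpropyl part would move the number. They also leave open whether the diethylamino group itself matters, which a dimethylamino group, a piperidine or a longer chain between the amide-type nitrogen and the amine could help to test.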